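Replacing phenylsulfamoyl with acetyl on the shared core

The compounds below may be only part of what the source reports. "The series", "measured", "known", "first", "only" and "open" are said of these compounds alone.

Three compounds have been measured so far in an ADME assay (liver) for metabolic stability, with Liver microsome (Rattus norvegicus) as the target, using microsomes and NADPH, with a stated time of 30 min (a lower number here means slower removal, a higher number faster removal of the compound), as follows:
- compound 1 `CC#C[C@H]1CN(S(=O)(=O)c2ccc(N)nc2)CCN1c1ccc(S(=O)(=O)NC)cn1` gives 42 mL.min-1.g-1 as its value
- compound 2 `CC#C[C@H]1CN(S(=O)(=O)c2ccc(N)nc2)CCN1c1ccc([C@@](O)(CO)C(F)(F)F)cc1` gives 53 mL.min-1.g-1 as its value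
- compound 3 `CC#C[C@H]1CN(S(=O)(=O)c2ccc(N)nc2)CCN1c1ccc(S(=O)(=O)Nc2ccccc2)cc1` gives > 399 mL.min-1.g-1 as a limit

Compound 3 stands at the limit of > 399 mL.min-1.g-1 in this assay, at which 1 of the 3 values shown sits, and that reading is a limit, not a number. Compound 4 `CC#C[C@H]1CN(S(=O)(=O)c2ccc(N)nc2)CCN1c1ccc(C(C)=O)cc1` has yet to be measured. It carries acetyl in place of phenylsulfamoyl on an aromatic carbon, para to a large group (acetyl in place of phenylsulfamoyl on an aromatic carbon).

Among the compounds with values here, one measured step bears on this change. Within the data shown here, in it phenylsulfamoyl enters at the same place, and it is an at least 7.5-fold higher number from compound 2 to compound 3 (0.87 log units; beyond the scatter) in this assay (the only step to hand). The change to compound 4 removes that group again, although acetyl is not the group that left in that step. Compound 1 at 42 mL.min-1.g-1 and compound 2 at 53 mL.min-1.g-1 mark where the two measured compounds without phenylsulfamoyl lie. A clear fall beyond the scatter is therefore expected, its full size being open since compound 3 has only a limit. The expected change is an at least 3.6-fold lower number from compound 3 to compound 4 (0.55 log units; beyond the scatter) on this estimate. For compound 4 the estimated value is 110 mL.min-1.g-1 with an expected range from 40 mL.min-1.g-1 to 300 mL.min-1.g-1 as the likely span.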

Compound 4, intrinsic clearance in microsomes: 249 mL.min-1.g-1
For compound 4 the middle estimate is 2.3-fold (0.35 log units) below the measured one, and the stated range covers the measured number.
By their numbers in this assay, from the lowest: compounds 1 and 2 (each within the scatter of the next); then compound 4. At a limit, above all of these: compound 3.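

Acetyl on this aromatic carbon does not bring the number in this assay down to the level of the diol-bearing group of compound 2: a 4.7-fold higher number from compound 2 to compound 4 (0.67 log units; beyond the scatter). A high number at this place therefore does not depend on the aromatic ring of phenylsulfamoyl, since a group with no ring also stands clearly above compound 2. The other step reads an at least 1.6-fold lower number from compound 3 to compound 4 (0.20 log units; that floor lies within the scatter), and because compound 3 is held only as a limit, not a number, the real size of that step stays unknown and its floor gives no firm sign of a fall: the limit of > 399 mL.min-1.g-1 in this assay, at which 1 of the 4 values shown sits.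

The compounds shown leave open whether the number at this place follows the carbonyl of acetyl or some other feature of the group, which a nitrile, a carboxylic acid or the alcohol corresponding to acetyl at the same aromatic carbon could help to separate. They also leave open how far compound 4 truly lies from compound 3, which only a number in place of that limit could settle.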